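Estimating a Fourth Sulfone From Three Measured Neighbours

The compounds below may be only part of what the source reports. "The series", "measured", "known", "first", "only" and "open" are said of these compounds alone.

Compound 1 `Cc1ccc(S(=O)(=O)c2cnc3cc(Cl)ccc3c2N2CCC(C)CC2)cc1F`: 85%
Compound 2 `COc1cccc(S(=O)(=O)c2cnc3cc(Cl)ccc3c2N2CCC(C)CC2)c1`: 93%
Compound 3 `COc1cccc(S(=O)(=O)c2cnc3cc(F)ccc3c2N2CCC(C)CC2)c1`: 90%

Three compounds have been run in an assay on isolated protein for displacement of a labelled ligand from metabotropic glutamate receptor 5 (Homo sapiens), with a stated time of 60 min, tested at 1 uM; on this read-out higher numbers stand for more inhibition at the one concentration tested (going by the name of the read-out) and lower numbers for less inhibition. Compound 2 gives 93% and stands as the starting point for two single changes. The first is 3-fluoro-4-methylphenyl in place of 3-methoxyphenyl on a sulfonyl sulfur, which produced a number 8 percentage points lower from compound 2 to compound 1 (within the scatter). The second is fluoro in place of chloro on an aromatic carbon, which produced a number 3 percentage points lower from compound 2 to compound 3 (within the scatter). Neither step leaves the usual spread of repeat measurements, so the three values cannot be ordered with confidence.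

Compound 4 `Cc1ccc(S(=O)(=O)c2cnc3cc(F)ccc3c2N2CCC(C)CC2)cc1F` has not been measured. It differs from compound 3 by 3-fluoro-4-methylphenyl in place of 3-methoxyphenyl on a sulfonyl sulfur. This is the same change that was made between compound 2 and compound 1, the place being the same in both cases, and its one measured outcome was a small downward step. The two cores on which the change is made differ by fluoro in place of chloro, as described for compound 2 and compound 3, and that difference itself gave only a small step.

Among the measured compounds shown here, compound 4 is therefore expected to sit a little under compound 3, and the expected step is a number 8 percentage points lower from compound 3 to compound 4 (within the scatter) in this assay , resting on the single earlier step of a number 8 percentage points lower from compound 2 to compound 1 (within the scatter). The estimate for compound 4 in this assay is 82%, with a likely range from 70% to 92%, and a limit rather than a number is not expected.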

Compound 4, a percentage reported as inhibition, at one concentration (the size of the read-out at that concentration, not a potency): 89%
Compound 4: the middle estimate sits 7 percentage points below what was measured; the range from low to high includes it.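

In this assay, the change to 3-fluoro-4-methylphenyl in place of 3-methoxyphenyl on a sulfonyl sulfur gave a number 1 percentage points lower from compound 3 to compound 4 (within the scatter), and this step does not differ meaningfully from the one seen earlier on the core of compound 2: the same change on two cores in this assay, a number 8 percentage points lower (within the scatter) from compound 2 to compound 1 and a number 1 percentage points lower (within the scatter) from compound 3 to compound 4, 7 percentage points apart, within the scatter of two such steps The other change, fluoro in place of chloro on an aromatic carbon, can now also be read with the 3-fluoro-4-methylphenyl group in place, where it gave a number 4 percentage points higher from compound 1 to compound 4 (within the scatter), and this too agrees with its earlier step: the same change on two cores in this assay, a number 3 percentage points lower (within the scatter) from compound 2 to compound 3 and a number 4 percentage points higher (within the scatter) from compound 1 to compound 4, 7 percentage points apart, within the scatter of two such steps The four compounds therefore give no sign that either change behaves differently from one core to the other, but every step here lies within the scatter, so they do not show that the steps are truly equal, or that either change has any real effect at all, and the comparison rests on a single pair of cores.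

These are readings at one concentration, so they say nothing about how potency might shift across the set. As far as these compounds go, it also remains open whether the same agreement would hold for an aryl group carrying a carboxylic acid or an amine on the sulfonyl sulfur, or for bromo in place of fluoro or chloro on the aromatic carbon.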